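Arylpiperazine amide series: benzisoxazole to cyanophenyl

The source may report more compounds than this note shows. Statements on the series, on what has been measured and on what is new or still open speak of the compounds shown alone.

Two compounds of this series carry a measurement in an assay on HEK293 cells for displacement of a labelled ligand from 5-hydroxytryptamine receptor 7 (Rattus norvegicus); a higher number here means a weaker inhibitor, a lower number a stronger inhibitor. Compound 1 `COc1ccccc1N1CCN(CCCC(=O)NC2CCCc3ccccc32)CC1` gives 92 nM in this assay. Compound 2 `O=C(CCCCCN1CCN(c2noc3ccccc23)CC1)NC1CCCc2ccccc21` gives 125 nM in this assay. Compound 2 has the higher of the two numbers, yet its gap to compound 1 lies within the scatter, so no order between them is claimed.

Compound 3 `N#Cc1ccc(N2CCN(CCCCCC(=O)NC3CCCc4ccccc43)CC2)cc1` is the next member and awaits measurement in this assay. It differs from compound 2 in one place: a group of 8 heavy atoms (7 carbon, 1 nitrogen; one six-membered aromatic ring of carbon only) in place of a group of 9 heavy atoms (7 carbon, 1 nitrogen, 1 oxygen; one five-membered aromatic ring with 2 hetero atoms, one six-membered aromatic ring of carbon only), on an amine nitrogen in a ring. Among the measured compounds shown here, no measured pair with this exchange exists, so its size is unknown here.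

The step from compound 2 to compound 3 is expected to be a 2.4-fold higher number from compound 2 to compound 3 (0.38 log units; beyond the scatter), a modest move toward a higher number, close to the scatter. Compound 3 is expected to give about 300 nM in this assay, within a range from 80 nM to 1200 nM.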

Compound 3, inhibition constant: 1400 nM
Compound 3: the middle estimate sits 4.7-fold (0.67 log units) below what was measured; the whole stated range lies below it.
By their numbers in this assay, from the lowest: compounds 1 and 2 (each within the scatter of the next); then compound 3.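

On an amine nitrogen in a ring, exchanging the group carried by compound 2 for 4-cyanophenyl gives an 11-fold higher number from compound 2 to compound 3 (1.05 log units; beyond the scatter) in this assay. This first measured exchange at the position shows that the aromatic groups placed there are not interchangeable: with the rest of the structure unchanged, this one exchange carries the number well beyond the scatter, so the group on this nitrogen can weigh heavily in this assay. Nothing available accounts for the size of the step.

Among the compounds shown here, the single pair cannot separate the contribution of the entering nitrile from that of the departing five-membered aromatic ring, and a plain phenyl or a 4-methoxyphenyl group on the same nitrogen would be needed to tell these apart. From the compounds shown here alone, whether a step of this size also holds on a shorter chain between the amide and the six-membered non-aromatic ring remains open as well, as does whether the result extends to other aromatic groups at this position.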